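The compounds below may be only part of what the source reports. "The series", "measured", "known", "first", "only" and "open" are said of these compounds alone.

- compound 1 `CC(C)=CC(=O)Nc1cc2c(N3CCCc4ccccc43)ncnc2cc1O[C@@H]1CCOC1`: 7910 nM
- compound 2 `O=C(/C=C/CN1CCCCC1)Nc1cc2c(N3CCc4ccccc43)ncnc2cc1O[C@@H]1CCOC1`: 4660 nM
- compound 3 `COc1cc2ncnc(N3CCCc4ccccc43)c2cc1NC(=O)/C=C/CN1CCCCC1`: 2880 nM

All three compounds were tested in a functional assay on A549 cells (Homo sapiens) for antiproliferative activity, read by MTT assay, with a stated time of 72 h; on this read-out lower numbers stand for stronger inhibition and higher numbers for weaker inhibition. There, compound 3 gives 2880 nM, at the low end of this small set. Its value lies within the scatter of that of compound 2, while compound 1 stands beyond the scatter on the weaker side of compound 3.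

The next compound, compound 4 `O=C(/C=C/CN1CCCCC1)Nc1cc2c(N3CCCc4ccccc43)ncnc2cc1O[C@@H]1CCOC1`, differs from compound 3 in one place: oxolan-3-yl in place of methyl on an oxygen on an aromatic ring. Among the compounds with values here, no pair of measured compounds differs by this change alone, so its size in this assay cannot be read directly. Within the data shown here, the only guide is indirect. Compound 2 already carries the (oxolan-3-yl)oxy group and gives 4660 nM. Compound 1 carries it too and gives 7910 nM. Neither value suggests a large drop in the number, though both compounds also differ from compound 3 elsewhere.

The expected change is a 1.3-fold higher number from compound 3 to compound 4 (0.12 log units; within the scatter), a small move toward a higher number that is not expected to pass beyond the scatter. For compound 4 the estimate is 3800 nM, with an expected range of 1400 nM to 9000 nM.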

Compound 4, half-maximal inhibitory concentration: 3670 nM
For compound 4 the middle estimate is 1.0-fold (0.02 log units) above the measured one; low and high end bracket the measured number.
By their numbers in this assay, from the lowest: compounds 3, 4, 2 and 1 (each within the scatter of the next, the first and the last beyond it).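

In this assay, the direct reading for this position is a 1.3-fold higher number from compound 3 to compound 4 (0.11 log units; within the scatter) when the methoxy on the aromatic ring becomes (oxolan-3-yl)oxy, so at this oxygen a larger group carrying a five-membered non-aromatic ring leaves the result inside the usual scatter with the rest of the molecule held constant. Within the data shown here, compound 4 also gives two further single-change readings: 1,2,3,4-tetrahydroquinolin-1-yl in place of 2,3-dihydro-1H-indol-1-yl on the aromatic carbon gives a 1.3-fold lower number from compound 2 to compound 4 (0.10 log units; within the scatter) and stays within the scatter, while 3-(piperidin-1-yl)prop-1-en-1-yl in place of 2-methylprop-1-en-1-yl on the carbonyl carbon gives a 2.2-fold lower number from compound 1 to compound 4 (0.33 log units; beyond the scatter) and is the only one of these steps that passes beyond it. Nothing among the data presented accounts for the size of any of these steps.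

Going by these compounds, it remains open whether a longer chain on the same oxygen, such as 2-methoxyethyl or a 2-(morpholin-4-yl)ethyl chain ending in an amine, would also stay within the scatter of compound 3. On these data alone, the opposite stereocentre of the oxolan-3-yl group also remains open, as does a dimethylamino group in place of the piperidin-1-yl group.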